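Working notes: amino to methoxy step, compound 3 to compound 4

The source may report more compounds than this note shows. Statements on the series, on what has been measured and on what is new or still open speak of the compounds shown alone.

Measured compounds:
compound 1 `O=C(/C=C/c1ccc2c(c1)B(O)OC2)c1ccccc1`: 2300 nM
compound 2 `O=C(/C=C/c1ccc2c(c1)B(O)OC2)c1cccc(F)c1`: 3000 nM
compound 3 `Nc1cccc(C(=O)/C=C/c2ccc3c(c2)B(O)OC3)c1`: 3200 nM

In a functional assay on MDA-MB-231 cells (Homo sapiens) for cytotoxicity, read by MTT assay, with a stated time of 48 h (on this read-out higher numbers stand for weaker inhibition and lower numbers for stronger inhibition), compound 3 gives the highest of the three numbers, yet its steps to compound 1 and to compound 2 both lie within the scatter, so no order among the three is claimed. The change to compound 4 `COc1cccc(C(=O)/C=C/c2ccc3c(c2)B(O)OC3)c1` is methoxy in place of amino on an aromatic carbon. Within the data shown here, the steps that bear on this place are a 1.4-fold higher number from compound 1 to compound 3 (0.14 log units; within the scatter) and a 1.1-fold higher number from compound 2 to compound 3 (0.03 log units; within the scatter), each within the scatter; every substitution so far at this aromatic carbon has left the number near that of compound 1. No step beyond the scatter is therefore expected, and the expected step is a 1.1-fold lower number from compound 3 to compound 4 (0.06 log units; within the scatter). For compound 4 the estimate in this assay is 2800 nM, with a range from 1400 nM to 5600 nM.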

Compound 4, half-maximal inhibitory concentration: 2100 nM
For compound 4 the middle estimate is 1.3-fold (0.12 log units) above the measured one, and the stated range covers the measured number.
By their numbers in this assay, from the lowest: compounds 4, 1, 2 and 3 (each within the scatter of the next).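

The steps of a 1.5-fold lower number from compound 3 to compound 4 (0.18 log units; within the scatter) and a 1.4-fold lower number from compound 2 to compound 4 (0.15 log units; within the scatter) and a 1.1-fold lower number from compound 1 to compound 4 (0.04 log units; within the scatter) all lie within the scatter in this assay and leave no order among hydrogen, fluoro, amino and methoxy at this aromatic carbon. Methoxy extends the earlier picture to a group of 2 heavy atoms with 0 hydrogen-bond donors, and the number still does not move beyond the scatter. No evidence is available on why the number holds at this place.

From the compounds shown here alone, whether a longer chain such as butoxy or a carboxylic acid at this carbon would give a step beyond the scatter remains open. Going by these compounds, the effect of substitution elsewhere on this ring also remains open.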